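Filling the para position of compound 2 with a methoxycarbonyl group

The source may report more compounds than this note shows. Statements on the series, on what has been measured and on what is new or still open speak of the compounds shown alone.

Of the compounds shown here, two from this series have been measured in a functional assay on K562 cells (Homo sapiens) for inhibition; a higher number here means a weaker inhibitor, a lower number a stronger inhibitor. Compound 1 `CCc1ccc(N2C(=O)C=CC2OCC(F)(F)F)cc1` gives 4470 nM, and compound 2 `O=C1C=CC(OCC(F)(F)F)N1c1ccccc1` gives 24600 nM. Of the two numbers, compound 2 carries the higher one, so it is the weaker inhibitor; the step of a 5.5-fold higher number from compound 1 to compound 2 (0.74 log units; beyond the scatter) shows how much the number rose when the ethyl group was replaced by hydrogen.

Compound 3 `COC(=O)c1ccc(N2C(=O)C=CC2OCC(F)(F)F)cc1` is not yet measured. It differs from compound 2 by methoxycarbonyl in place of hydrogen on an aromatic carbon. Among the compounds with values here, the only measured step that bears on this change is the one from compound 1 to compound 2, where a group at that same place was removed and the number rose by a modest amount. Putting a group back at that place might therefore be expected to lower the number again, although methoxycarbonyl is a different group from ethyl, and nothing in the measured pair shows what this particular group does.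

On that basis the number for compound 3 in this assay is expected to move by a 2.7-fold lower number from compound 2 to compound 3 (0.44 log units; beyond the scatter), giving an estimate of 9000 nM with a likely range from 2500 nM to 30000 nM.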

Compound 3, half-maximal inhibitory concentration: 14700 nM
Estimate against measurement, compound 3: 1.6-fold (0.21 log units) below; the range from low to high includes it.
By their numbers in this assay, from the lowest: compound 1; then compounds 3 and 2 (each within the scatter of the next).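

In this assay, methoxycarbonyl on the aromatic carbon that carries hydrogen in compound 2 gives a 1.7-fold lower number from compound 2 to compound 3 (0.22 log units; within the scatter) and so cannot be told apart from hydrogen at this place. Methoxycarbonyl in place of ethyl gives a 3.3-fold higher number from compound 1 to compound 3 (0.52 log units; beyond the scatter) and shows that simply filling this position is not enough, since the outcome depends on which group sits there: ethyl separates from hydrogen beyond the scatter, whereas methoxycarbonyl does not. The available data offer no explanation for this difference between ethyl and methoxycarbonyl.

Within the data shown here, the three compounds give only two substituted examples at this place, so they leave open whether a longer chain such as propyl would carry the trend seen with ethyl any further. They also leave open how an amine or a carboxylic acid at the same carbon would compare with ethyl and methoxycarbonyl, and whether any such group could bring the number lower than the value for compound 1, 4470 nM in this series.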